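From compound 2 to compound 4: one aromatic group exchanged

This account rests on a few compounds, and the source may have more. Where it says the series, first, only, none or still open, it means among the compounds named here.

Measured in a physicochemical assay for lipophilicity, using the shake flask method, in phosphate buffer, measured as octanol-water partition, with a stated time of 30 min, at pH 7.4; on this read-out lower numbers stand for lower lipophilicity and higher numbers for higher lipophilicity:
- compound 1 `Fc1ccc2c(c1CNc1ncc(Oc3ccccc3)c3nncn13)CCO2` gives 3.5
- compound 2 `Cn1nccc1-c1cnc(NCc2c(F)ccc3c2CCO3)c2cn[nH]c(=O)c12` gives 2.6
- compound 3 `COCCC(=O)Nc1cnc(NCc2c(F)ccc3c2CCO3)n2cnnc12` gives 1.4

Compound 2 at 2.6 holds the middle place of the three, in an order that runs from compound 1 at 3.5 down to compound 3 at 1.4 with both gaps beyond the scatter.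

Compound 4 `Cc1ncc(-c2cnc(NCc3c(F)ccc4c3CCO4)c3cn[nH]c(=O)c23)n1C` is not yet measured. It carries 1,2-dimethyl-1H-imidazol-5-yl in place of 1-methyl-1H-pyrazol-5-yl on an aromatic carbon and is otherwise the same as compound 2.

Among the measured compounds shown here, only one measured step is available, and it bears on this change only indirectly. The step of a number 2.10 log units lower from compound 1 to compound 3 (beyond the scatter) is large and beyond the scatter, but it exchanges quite different groups on another core. It shows that this assay can move far with a single exchange on an aromatic carbon, and it gives no size for the present one. For the measured compounds named here, no measured step exchanges one of these five-membered aromatic groups for the other, so direction and size remain a judgement.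

A modest fall is expected, and the estimated step is a number 0.40 log units lower from compound 2 to compound 4 (beyond the scatter) with real doubt over its sign. In this assay the estimated value for compound 4 is 2.2 with an expected range of 1.7 to 2.8 awaiting measurement.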

Compound 4, distribution coefficient: 1.9
The estimate for compound 4 lay 0.30 log units above the measured number; the measured number falls inside the stated range.
By their numbers in this assay, from the lowest: compound 3; then compound 4; then compound 2; then compound 1.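

In this assay, among the compounds shown here, the exchange of 1-methyl-1H-pyrazol-5-yl for 1,2-dimethyl-1H-imidazol-5-yl gives a number 0.70 log units lower from compound 2 to compound 4 (beyond the scatter), which fixes the sign that the earlier compounds left open: the number falls even though the entering group has 7 heavy atoms against 6. The two groups match in their counts of hydrogen-bond donors and acceptors and in net charge, and each is a five-membered aromatic ring with 2 hetero atoms, so these counts do not separate them, yet this place on the aromatic carbon, para to a large group, still registers the exchange beyond the scatter. Nothing measured on these compounds accounts for the fall.

The compounds shown leave open how the step divides between the change of ring and the added methyl, and a 1-methyl-1H-imidazol-5-yl group at this place would separate the two. Also open, as far as these compounds go, is how the read-out responds here to a group of another kind, such as an amine or a carboxylic acid, and whether the same exchange gives a similar step on another core.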